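Methoxy on the Pyranone Aryl Ring: Cytotoxicity Notes

A few compounds are considered here, and "the series" means these few. Any claim that something is new, unique, unknown or untested is made for them only; others in the source may bear on it.

Measured compounds:
- compound 1 `COc1ccc(-c2cc(NO)c(C(=O)Nc3ccccc3)c(=O)o2)cc1` — 16200 nM
- compound 2 `O=C(NCc1ccccc1)c1c(NO)cc(-c2ccccc2)oc1=O` — > 20000 nM (assay limit)

In an ADME assay on Huh-7 cells (Homo sapiens) for cytotoxicity, read by a luciferase reporter and WST assay, with a stated time of 3 days (a higher number here means that more compound is tolerated, a lower number that less compound is tolerated), compound 1 gives 16200 nM. Compound 2 reaches only the limit of > 20000 nM in this assay, so no number is known for it, and the limit of > 20000 nM in this assay, at which 1 of the 2 values shown sits, marks where it sits. Compound 1 differs from compound 2 in more than one place, so the two values show only that the first is a number and the second a limit.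

Compound 3 `COc1ccc(-c2cc(NO)c(C(=O)NCc3ccccc3)c(=O)o2)cc1` is the next step: methoxy in place of hydrogen on an aromatic carbon. The entering group is methoxy, set on an aromatic carbon of a six-membered aromatic ring of carbon only, para to a large group; the change read one bond further out is phenyl to 4-methoxyphenyl. Within the data shown here, no measured step carries this change alone, so no step beyond the scatter is expected in this assay, in either direction. Compound 3 is expected at 18000 nM, between 9000 nM and 40000 nM. The expected step is an at least 1.1-fold lower number from compound 2 to compound 3 (0.04 log units; that floor lies within the scatter), within the scatter, with a fair chance that only a limit is again reported.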

Compound 3, half-maximal cytotoxic concentration: > 20000 nM
Compound 3 was reported as a limit; the forecaster's own chance of this, stated with the estimate: 55%; at least 1.1-fold (0.04 log units) between middle value and limit.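

Compound 3, which carries methoxy in place of hydrogen on an aromatic carbon, is reported only as a limit in this assay, and this is the same limit as for compound 2: the limit of > 20000 nM in this assay, at which 2 of the 3 values shown sit. From the compounds shown here alone, the step between these two compounds cannot be read, as both ends are limits, so any effect of methoxy at this place remains unknown. The new readable comparison concerns the amide-type nitrogen, where benzyl in place of phenyl gives an at least 1.2-fold higher number from compound 1 to compound 3 (0.09 log units; that floor lies within the scatter), so this change is not shown to go beyond the scatter.

Going by these compounds, whether methoxy has any effect on this read-out stays open while both benzyl amides rest at the limit. Also open, on these data alone, is whether an amine or a carboxylic acid at this place, or a longer chain on the amide-type nitrogen, would give a number rather than a limit.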